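The source may hold more compounds than are shown below. What is called first, only, known or untested is meant among the compounds shown, and "the series" means these compounds.

Working notes on the series. In an assay for inhibition of steroid 17-alpha-hydroxylase/17,20 lyase (Homo sapiens), using NADPH, tested at 2 uM (a lower number here means a weaker effect, a higher number a stronger effect of the compound at the concentration tested), compound 1 `CCC(c1ccc(-c2cscc2C)cc1)n1ccnc1` gives 84%. Compound 3 `c1cncc(-c2ccc(Cn3ccnc3)cc2)c1` gives 14% in this assay, and compound 2 `Fc1ccc(-c2ccc(Cn3ccnc3)cc2)cn1` gives 13%. Between them lies the change (fluoro in place of hydrogen on an aromatic carbon), and the step is a number 1 percentage points lower from compound 3 to compound 2 (within the scatter). The difference between the core of compound 1 and that of compound 3 is not broken down here.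

Compound 4 `CCC(c1ccc(-c2cscc2C)cc1F)n1ccnc1`, not yet measured, differs from compound 1 by fluoro in place of hydrogen on an aromatic carbon. This is the same kind of change as from compound 3 to compound 2, not the same: there the fluoro enters on a six-membered aromatic ring with one nitrogen, next to the ring nitrogen, para to a large group; here on a six-membered ring of carbon only, ortho to a group of 8 heavy atoms, meta to a 4-methylthiophen-3-yl group.

In this assay, within the data shown here, a step of a number 4 percentage points lower from compound 1 to compound 4 (within the scatter) is expected, resting on the single earlier instance a number 1 percentage points lower from compound 3 to compound 2 (within the scatter) being within the scatter. For compound 4 the estimate is 80%, between 60% and 92%.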

Compound 4, a percentage reported as inhibition, at one concentration (the size of the read-out at that concentration, not a potency): 92%
Beside the measured number, compound 4's estimate is 12 percentage points below it; the range from low to high includes it.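

In this assay, fluoro in place of hydrogen on an aromatic carbon gives a number 8 percentage points higher from compound 1 to compound 4 (within the scatter). Set beside the earlier step, the change reads the same on both cores: the same change on two cores in this assay, a number 1 percentage points lower (within the scatter) from compound 3 to compound 2 and a number 8 percentage points higher (within the scatter) from compound 1 to compound 4, 9 percentage points apart, within the scatter of two such steps. This rests on only two instances, on different rings, with compound 3 at 14% and compound 1 at 84%, and does not show that the change would stay within the scatter on any other core in the series.

The compounds shown leave open whether a chloro, a methoxy or an amine on the same aromatic carbon would also stay within the scatter. They also leave open what fluoro does on the other carbons of that ring.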